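The source may report more compounds than this note shows. Statements on the series, on what has been measured and on what is new or still open speak of the compounds shown alone.

Measured compounds:
- compound 1 `Sc1nccn1CCCc1ccccc1`: 16000 nM
- compound 2 `CC(Cc1ccccc1)Cn1ccnc1S`: 29000 nM

Both were run in an assay on isolated protein for inhibition of Dopamine beta-hydroxylase (Bos taurus); on this read-out lower numbers stand for stronger inhibition and higher numbers for weaker inhibition. Compound 1 gives 16000 nM, the lowest of the two numbers; its nearest neighbour is compound 2, and the step of a 1.8-fold higher number from compound 1 to compound 2 (0.26 log units; within the scatter) lies within the scatter, so the two values cannot be ordered.

The next compound in the series is compound 3 `Oc1ccc(CCCn2ccnc2S)cc1`, which differs from compound 1 as follows: hydroxy in place of hydrogen on an aromatic carbon. Within the data shown here, this change sits on the aromatic ring, whereas the only measured step, from compound 1 to compound 2, alters a saturated chain carbon and is itself within the scatter. Among the measured compounds shown here, no measured step therefore bears directly on a hydroxy entering on the aromatic ring, and the series gives no guide to its direction. In the absence of a relevant step, the expected step of a 1.3-fold lower number from compound 1 to compound 3 (0.12 log units; within the scatter) is taken as small and not beyond the scatter. Compound 3 is accordingly estimated at 12000 nM in this assay, with a range from 2500 nM to 60000 nM.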

Compound 3, half-maximal inhibitory concentration: 2200 nM
Compound 3: the middle estimate sits 5.5-fold (0.74 log units) above what was measured; measured number below the stated range.
By their numbers in this assay, from the lowest: compound 3; then compounds 1 and 2 (each within the scatter of the next).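

In this assay, hydroxy in place of hydrogen on an aromatic carbon, para to a group of 9 heavy atoms, gives a 7.3-fold lower number from compound 1 to compound 3 (0.86 log units; beyond the scatter). Among these compounds, this is the first step beyond the scatter: the earlier step, methyl in place of hydrogen on a saturated chain carbon, could not be told from the scatter, and the six-membered aromatic ring is now the first place where a single change is seen to move the number. Nothing measured on the series accounts for the size or direction of this step.

Still open, from the compounds shown here alone, is whether the lower number belongs to the hydroxy as such, or whether a methoxy, a fluorine or an amine at the same place on the ring would give a similar step, and whether a hydroxy elsewhere on that ring would match it. Also open, going by these compounds, is how the hydroxy step carries over to other chains, such as the methyl-bearing chain of compound 2 or a shorter or longer chain between the aromatic ring and the shared core.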